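Series notes: heteroaryl exchange on the chain carbon

The compounds below may be only part of what the source reports. "The series", "measured", "known", "first", "only" and "open" are said of these compounds alone.

The shared core is seen in compound 1 `CCOC(=O)c1c(C)noc1OCC(=O)[C@H](CC(=O)O)NC(=O)[C@@H](NC(=O)COc1cccc2ccccc12)C(C)C`, compound 2 `CC(C)[C@H](NC(=O)COc1cccc2ccccc12)C(=O)N[C@@H](CC(=O)O)C(=O)CSc1nnc(-c2ccccc2)o1` and compound 3 `CC(C)[C@H](NC(=O)COc1cccc2ccccc12)C(=O)N[C@@H](CC(=O)O)C(=O)CSc1nc2ccccc2o1`; the three differ only in the group on a saturated chain carbon bound to a carbonyl carbon. In a functional assay on Jurkat cells (Homo sapiens) for inhibition (on this read-out higher numbers stand for weaker inhibition and lower numbers for stronger inhibition), compound 2 gives 150000 nM. Compound 1 reaches only the limit of > 200000 nM in this assay. Compound 3 likewise stands at the limit of > 200000 nM. That is the limit of > 200000 nM in this assay, at which 2 of the 3 values shown sit, so compound 3 has no readable number of its own. The measured steps are all weak or unreadable: an at least 1.3-fold higher number from compound 2 to compound 3 (0.12 log units; that floor lies within the scatter), an at least 1.3-fold lower number from compound 1 to compound 2 (0.12 log units; that floor lies within the scatter), and a step that the two limits leave unreadable from compound 1 to compound 3.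

Compound 4 `CC(C)[C@H](NC(=O)COc1cccc2ccccc12)C(=O)N[C@@H](CC(=O)O)C(=O)COn1nnc2ccccc2c1=O` differs from compound 3 by a group of 12 heavy atoms (7 carbon, 3 nitrogen, 2 oxygen; one six-membered aromatic ring of carbon only, one six-membered aromatic ring with 3 hetero atoms) in place of a group of 10 heavy atoms (7 carbon, 1 nitrogen, 1 oxygen, 1 sulfur; one five-membered aromatic ring with 2 hetero atoms, one six-membered aromatic ring of carbon only), on a saturated chain carbon bound to a carbonyl carbon. Every measured step in the series exchanges the group at this same position, and none of them moves this assay beyond the scatter, so for compound 4 no step beyond the scatter is expected either, in no particular direction. Compound 4 is therefore expected at 200000 nM, with a range from 90000 nM to 450000 nM, and most probably the assay will again report only a limit. The expected step of a number no higher from compound 3 to compound 4 (the limit leaves the size open) thus stays within the scatter.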

Compound 4, half-maximal inhibitory concentration: 137000 nM
Compound 4: the middle estimate sits 1.5-fold (0.16 log units) above what was measured; the measured number falls inside the stated range.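

Among the compounds shown here, at the saturated chain carbon bound to a carbonyl carbon, compound 4 joins compound 2 as the only other compound with a readable number in this assay, and this pair gives the series its first comparison of two numbers, not limits: a 1.1-fold lower number from compound 2 to compound 4 (0.04 log units; within the scatter). One group of 12 heavy atoms, with a six-membered aromatic ring with 3 hetero atoms, thus stands in place of another with a five-membered aromatic ring with 3 hetero atoms, and the read-out does not move beyond the scatter. Against the two compounds held at a limit, the floors are an at least 1.4-fold lower number from compound 3 to compound 4 (0.16 log units; that floor lies within the scatter) and an at least 1.4-fold lower number from compound 1 to compound 4 (0.16 log units; that floor lies within the scatter), so neither shows a step beyond the scatter, and compound 1 and compound 3 still have no number of their own: the limit of > 200000 nM in this assay, at which 2 of the 4 values shown sit.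

The compounds shown leave open whether a group with no aromatic ring at this chain carbon, such as a simple amine or a single fluorine atom, would move this assay beyond the scatter. They also leave open whether a change elsewhere, such as an amide in place of the carboxylic acid of the shared core, would do so.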